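The source may report more compounds than this note shows. Statements on the series, on what has been measured and on what is new or still open speak of the compounds shown alone.

Measured so far:
- Compound 1, `O=C([C@@H]1CCCN(S(=O)(=O)c2ccc(S(=O)(=O)N3CC[C@@H](O)C3)cc2)C1)N1CCC(F)(F)CC1`, gives 210 nM in a functional assay on MIA PaCa-2 cells (Homo sapiens) for inhibition, read by MTT assay, with a stated time of 7 days; on this read-out higher numbers stand for weaker inhibition and lower numbers for stronger inhibition
- Compound 2, `CCN(CC)S(=O)(=O)c1ccc(S(=O)(=O)N2CCC[C@@H](C(=O)NC3CCOCC3)C2)cc1`, gives 3770 nM in this assay

Of the two numbers shown, compound 1 has the lowest, and the gap from it to compound 2 is well beyond the usual scatter of repeated measurements, so compound 1 is the stronger inhibitor of this pair. For the measured compounds named here, compound 2 differs from compound 1 in several places at once, so no single step between them can be read.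

The next compound, compound 3, `O=C([C@@H]1CCCN(S(=O)(=O)c2ccc(S(=O)(=O)N3CC[C@H](O)C3)cc2)C1)N1CCC(F)(F)CC1`, is the mirror-image partner of compound 1 at one point only: the two compounds have the same atoms and bonds and differ only in configuration as drawn: 1 of 2 stereo elements differ; a stereocentre at a saturated ring carbon is drawn R in compound 1 and S in compound 3 Nothing is added and nothing is removed; only the spatial arrangement at that one carbon is changed.

Going by the values given here, no earlier measured pair shows how such a change in configuration plays out in this assay, so the expected step is uncertain; the step from compound 1 to compound 3 is expected to be small, at most a modest weakening, a 1.7-fold higher number from compound 1 to compound 3 (0.22 log units; within the scatter), and may lie within the scatter. Compound 3 is therefore estimated at 350 nM, with a plausible range from 120 nM to 1200 nM.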

Compound 3, half-maximal inhibitory concentration: 590 nM
For compound 3 the middle estimate is 1.7-fold (0.23 log units) below the measured one; measured number inside the range.
By their numbers in this assay, from the lowest: compound 1; then compound 3; then compound 2.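

Read in this assay, this pair gives the first direct view of what configuration alone does in this series: turning a stereocentre at a saturated ring carbon from R to S brings a 2.8-fold higher number from compound 1 to compound 3 (0.45 log units; beyond the scatter). The step is modest, but it shows that this one carbon is not indifferent to its spatial arrangement, and that the R form, compound 1, is the stronger inhibitor of the two. The gap can be assigned to that single carbon, and not to any added or removed group, because the pair holds everything else constant: the fact that compounds 1 and 3 differ only in the configuration as drawn.

The compounds shown do not reveal how the arrangement at this carbon produces the gap, nor what happens when the other stereo element, drawn the same in compound 1 and compound 3, is inverted. They also leave open whether the same preference for R would survive if the hydroxyl group were replaced by a methoxy group or an amine, since both configurations are shown here with the hydroxyl group alone.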